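Chloro to bromo on the aryloxy group of compound 1

A few compounds are considered here, and "the series" means these few. Any claim that something is new, unique, unknown or untested is made for them only; others in the source may bear on it.

Among the measured compounds shown here, compound 1 `NC1=NC2(CCOCC2)N(OCCCOc2ccc(Cl)cc2)C(N)=N1` is the only member of the series with a number: in an assay on isolated protein for inhibition of Dihydrofolate reductase (Homo sapiens), read by spectrophotometry, using NADPH, with stated times of 5 s and 6 min (a lower number here means a stronger inhibitor, a higher number a weaker inhibitor), compound 1 gives 33.6 nM. Compound 2 `NC1=NC2(CCSCC2)N(OCCCOc2cc(Cl)c(Cl)cc2Cl)C(N)=N1` carries a different core and a different aryloxy group, and in this assay compound 2 gives "not determined" (no result reported). Compound 3 `NC1=NC2(CCOCC2)N(OCCCOc2ccc(Br)cc2)C(N)=N1` differs from compound 1 by bromo in place of chloro on an aromatic carbon. For the measured compounds named here, no measured step of this kind is in hand, so the step from compound 1 to compound 3 is expected to be small, at most near the scatter, with potency close to that of compound 1 a 1.1-fold lower number from compound 1 to compound 3 (0.05 log units; within the scatter). Compound 3 is estimated at 30 nM, within 15 nM to 70 nM.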

Compound 3, half-maximal inhibitory concentration: 32.5 nM
Compound 3: the middle estimate sits 1.1-fold (0.03 log units) below what was measured; the range from low to high includes it.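

Among the compounds shown here, the step of a 1.0-fold lower number from compound 1 to compound 3 (0.01 log units; within the scatter) in this assay is the first measured one, and it shows that chloro and bromo on this aromatic carbon read alike. At this place, one halogen can therefore stand in for the other without a readable shift in this read-out. Nothing in hand bears on why the two read alike.

Open, as far as these compounds go, is whether the same holds for a group other than a halogen here, such as methoxy, nitrile or a carboxylic acid. Also open, from the compounds shown here alone, is how a longer chain between the core and the aryloxy group would read.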